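The compounds below may be only part of what the source reports. "The series", "measured", "known", "first", "only" and "open" are said of these compounds alone.

Working notes on the series. Compound 1 `CC1CCC(=O)N1CC#CCn1ccnc1` and compound 2 `Cc1cncn1CC#CCN1C(=O)CCC1C` share one core; compound 3 `COC(=O)N(C)CC#CCn1ccnc1` and the as yet unmeasured compound 4 `COC(=O)N(C)CC#CCn1cncc1C` share another, and the difference between the two cores is not broken down here. In a functional assay on the whole organism for antagonist activity, with Mus musculus as the target (on this read-out higher numbers stand for an effect only at larger amounts of compound and lower numbers for an effect already at smaller amounts), compound 1 gives 0.54 mg/kg. In this assay compound 2 gives 0.8 mg/kg. The change between them is methyl in place of hydrogen on an aromatic carbon, and it produced a 1.5-fold higher number from compound 1 to compound 2 (0.17 log units; within the scatter). For compound 3 this assay reports only a limit, > 100 mg/kg; this is the limit of > 100 mg/kg in this assay, at which 1 of the 3 values shown sits, and no number stands behind it. Compound 4 differs from compound 3 by methyl in place of hydrogen on an aromatic carbon, the same change as from compound 1 to compound 2, since both place descriptions agree word for word. The step expected from compound 3 to compound 4 in this assay is a step that the limit leaves unreadable from compound 3 to compound 4, set beside the measured one; it rests on compound 1 to compound 2 having given a 1.5-fold higher number from compound 1 to compound 2 (0.17 log units; within the scatter), a shift that stays within the scatter. For compound 4 the estimate in this assay is therefore 150 mg/kg, with a range from 60 mg/kg to 400 mg/kg, and most likely the read-out will again stop at a limit.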

Compound 4, dose for half-maximal effect: 3 mg/kg
Estimate against measurement, compound 4: 50-fold (1.70 log units) above; the measured number lies below the stated range.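

In this assay methyl in place of hydrogen on an aromatic carbon gave an at least 33-fold lower number from compound 3 to compound 4 (1.52 log units; beyond the scatter) and so did not carry over from one core to the other with the same size: the same change on two cores in this assay, a 1.5-fold higher number (0.17 log units; within the scatter) from compound 1 to compound 2 and an at least 33-fold lower number (1.52 log units; beyond the scatter) from compound 3 to compound 4, at least 49-fold (1.69 log units) apart, beyond the scatter of two such steps

The step on the core of compound 3 is only a bound, since compound 3 stands at a limit: the limit of > 100 mg/kg in this assay, at which 1 of the 4 values shown sits.

What the two pairs do not show is why the steps differ: with one pair on each core and the difference between the cores not broken down, nothing ties the gap to any one feature of either core, and no rule for further cores follows.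

The compounds shown leave open whether a group other than methyl on the same aromatic carbon, such as ethyl or chlorine, would also give a large step on the core of compound 3 and a step within the scatter on the core of compound 1. Also open, going by these compounds, is how a third core would respond to the same methyl.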